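Quaternary ammonium chain variants in a collagen promoter reporter

The source may hold more compounds than are shown below. What is called first, only, known or untested is meant among the compounds shown, and "the series" means these compounds.

Measured compounds:
compound 1 `CN(C)c1ccc2c(=O)c(C(=O)Nc3cc(F)cc(F)c3)cn(-c3ccc(OCCCCCCC[N+]4(C)CCCCC4)cc3Cl)c2n1` — "not active" (no number reported)
compound 2 `CC[N+]1(CCCCCCCOc2ccc(-n3cc(C(=O)Nc4cc(F)cc(F)c4)c(=O)c4ccc(N(C)C)nc43)cc2C)CCCCC1` — 19.7%
compound 3 `CC[N+]1(CCCCCCCOc2ccc(-n3cc(C(=O)Nc4cc(F)cc(F)c4)c(=O)c4ccc(N(C)C)nc43)cc2Cl)CCCCC1` — 14.3%

Among the measured compounds shown here, in an assay on LX2 cells for inhibition of COL1A1 promoter (Homo sapiens), read by a luciferase reporter, with a stated time of 24 h, tested at 20 uM (on this read-out lower numbers stand for a weaker effect and higher numbers for a stronger effect at the one concentration tested), compound 3 gives 14.3%, and compound 2 gives 19.7%; the only step between them, a number 5.4 percentage points lower from compound 2 to compound 3 (within the scatter), is within the scatter. Compound 1 is reported without a number.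

Compound 4 `CN(C)c1ccc2c(=O)c(C(=O)Nc3cc(F)cc(F)c3)cn(-c3ccc(OCCCCCCC[N+](C)(C)C4CCCCC4)c(Cl)c3)c2n1` differs from compound 3 by a group of 9 heavy atoms (8 carbon, 1 nitrogen; one six-membered non-aromatic ring of carbon only) in place of a group of 8 heavy atoms (7 carbon, 1 nitrogen; one six-membered non-aromatic ring with 1 hetero atom), on a saturated chain carbon, seven bonds along the chain from an oxygen on an aromatic ring. For the measured compounds named here, no measured step touches this end of the chain, so the expectation rests on compound 3 alone. The step expected is a number 2.3 percentage points lower from compound 3 to compound 4 (within the scatter), i.e. none beyond the scatter. In this assay compound 4 is estimated at 12%, within 0% to 28%; compound 1 reporting no number leaves a chance that compound 4 also returns none.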

Compound 4, a percentage reported as inhibition, at one concentration (the size of the read-out at that concentration, not a potency): 34.8%
Compound 4: middle estimate off by 22.8 percentage points, on the low side; the measured number lies above the stated range.
By their numbers in this assay, from the lowest: compounds 3 and 2 (each within the scatter of the next); then compound 4.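

In this assay, the end of the chain responds where the aromatic carbon did not: the open-chain ammonium bearing a six-membered ring of carbon only, in place of the ring with 1 hetero atom, gives a number 20.5 percentage points higher from compound 3 to compound 4 (beyond the scatter) and so moves beyond the scatter, unlike a number 5.4 percentage points lower from compound 2 to compound 3 (within the scatter) on the aromatic carbon. No measured evidence here accounts for this step.

From the compounds shown here alone, a single pair carries this result, so it remains open whether a cyclopentyl ring or a morpholine ring at the chain end would follow compound 4 or compound 3. Going by these compounds, a shorter chain carrying the group of compound 4 also remains open.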